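This account rests on a few compounds, and the source may have more. Where it says the series, first, only, none or still open, it means among the compounds named here.

Compound 1, `Cc1ccc(C2=NN(c3nc(-c4ccc(Cl)cc4)cs3)C(c3ccc(F)cc3)C2)s1`, was tested in an ADME assay on NIH3T3 cells (Mus musculus) for cytotoxicity, read by XTT assay, with a stated time of 24 h; a lower number here means a stronger inhibitor, a higher number a weaker inhibitor. In this assay compound 1 gives > 500 ug/mL, which is a limit of the assay and not a measured number. Compound 2, `N#Cc1ccc(-c2csc(N3N=C(c4ccc(Cl)s4)CC3c3ccc(F)cc3)n2)cc1`, shares the core of compound 1 and was tested in the same way. In this assay compound 2 gives > 500 ug/mL, again a limit rather than a number. Going by the values given here, compound 1 therefore stands exactly where every value shown stands: at the limit of > 500 ug/mL in this assay, at which 2 of the 2 values shown sit, so no step between two measured compounds can be drawn, and no direction of change is known from the data.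

Compound 3, `Cc1ccc(C2=NN(c3nc(-c4ccccc4)cs3)C(c3ccc(F)cc3)C2)s1`, has not yet been measured. It differs from compound 1 by hydrogen in place of chloro on an aromatic carbon, a very small change at the edge of the molecule. The step expected in this assay is a number no higher from compound 1 to compound 3 (the limit leaves the size open), that is, none beyond the usual scatter, since compound 1 gives > 500 ug/mL only as a limit. Compound 3 is thus expected to give 500 ug/mL, within a range from 250 ug/mL to 1000 ug/mL.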

Compound 3, half-maximal inhibitory concentration: > 500 ug/mL
Compound 3 ended at the assay's limit; the forecaster's own chance of this, stated with the estimate: 85%; the middle value sits exactly at the limit.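

In this assay compound 3 gives > 500 ug/mL as a limit of the assay and not as a number. Going by these compounds alone, compound 1 also stands at a limit, so no step from compound 1 to compound 3 can be read: the limit of > 500 ug/mL in this assay, at which 3 of the 3 values shown sit. The compounds shown leave open how far their true values lie from that limit, and whether in this assay hydrogen in place of chloro makes any difference.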